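Ring-nitrogen side chain swap on the amide series

The source may hold more compounds than are shown below. What is called first, only, known or untested is meant among the compounds shown, and "the series" means these compounds.

Measured so far in a functional assay on a cell-free system (Platelet, plasma, Homo sapiens) for inhibition; on this read-out higher numbers stand for weaker inhibition and lower numbers for stronger inhibition:
compound 1 `CC(CC(=O)O)N1Cc2ccc(NC(=O)CCCC3CCNCC3)cc2C1=O` gives 5400 nM
compound 2 `CC(CC(=O)O)N1Cc2ccc(NC(=O)c3ccc4c(c3)CNCC4)cc2C1=O` gives 86 nM
compound 3 `O=C(O)CCCN1Cc2ccc(NC(=O)CCCC3CCNCC3)cc2C1=O` gives 51000 nM

Compound 2 stands lowest of the three in this assay, with compounds 1 and 3 both beyond the scatter above it. Compound 1 and compound 3 share their core and differ only in the side chain on the ring nitrogen: the change is 3-carboxypropyl in place of 1-(carboxymethyl)ethyl on an amide-type nitrogen in a ring, and it produced a 9.4-fold higher number from compound 1 to compound 3 (0.98 log units; beyond the scatter). How the cores of compound 1 and compound 2 differ is not broken down here.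

Compound 4 `O=C(O)CCCN1Cc2ccc(NC(=O)c3ccc4c(c3)CNCC4)cc2C1=O` is not yet measured. It relates to compound 2 as compound 3 relates to compound 1: the change is 3-carboxypropyl in place of 1-(carboxymethyl)ethyl on an amide-type nitrogen in a ring, at a place described in the same words as for the pair of compound 1 and compound 3, so it is the same change on a different core.

Going by the values given here, since the only precedent is a 9.4-fold higher number from compound 1 to compound 3 (0.98 log units; beyond the scatter), the expected step is a 9.3-fold higher number from compound 2 to compound 4 (0.97 log units; beyond the scatter), resting on that single pair. Compound 4 is therefore estimated at 800 nM in this assay, expected to fall between 250 nM and 2600 nM.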

Compound 4, half-maximal inhibitory concentration: 330000 nM
Estimate against measurement, compound 4: 410-fold (2.62 log units) below, and the stated range ends below it.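

In this assay, 3-carboxypropyl in place of 1-(carboxymethyl)ethyl on the ring nitrogen gives a 3800-fold higher number from compound 2 to compound 4 (3.58 log units; beyond the scatter). The direction of the step is the same on both cores, but its size does not carry from one core to the other: the same change on two cores in this assay, a 9.4-fold higher number (0.98 log units; beyond the scatter) from compound 1 to compound 3 and a 3800-fold higher number (3.58 log units; beyond the scatter) from compound 2 to compound 4, 410-fold (2.61 log units) apart, beyond the scatter of two such steps. This shows that, in these two pairs, the size of the change depends on the core it sits on; it does not show which feature of the cores sets the size, and two pairs give no rule for a further core.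

Still open, going by these compounds, is how the step behaves with other side chains on the same ring nitrogen, such as a 2-carboxyethyl or a 4-carboxybutyl chain, on either core. Also open is which part of the group on the amide nitrogen outside the ring system separates the two cores, as the compounds shown do not break that difference down.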